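The source may hold more compounds than are shown below. What is called first, only, known or untested is meant among the compounds shown, and "the series" means these compounds.

Two compounds of the series have numbers in a functional assay on HOS-TE85 cells (Homo sapiens) for inhibition, read by CCK-8 assay, with a stated time of 72 h, tested at 1 uM; a higher number here means more inhibition at the concentration tested (going by the name of the read-out), a lower number less inhibition. Compound 1 `O=C(NCCCCc1ccccc1)c1cccc(C2SCC(=O)N2c2cccc(F)c2)c1` gives 94%. Compound 2 `CCN1C(=O)CSC1c1cccc(C(=O)NCCCCc2ccccc2)c1` gives 0%, the lower of the two numbers; its nearest neighbour is compound 1, and the step of a number 94 percentage points lower from compound 1 to compound 2 (beyond the scatter) lies beyond the scatter. Compound 3 `COc1c(F)cccc1N1C(=O)CSC1c1cccc(C(=O)NCCCCc2ccccc2)c1` has not yet been measured in this assay. It differs from compound 2 by 3-fluoro-2-methoxyphenyl in place of ethyl on an amide-type nitrogen in a ring.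

Among the measured compounds shown here, the one measured step that bears on this change is a number 94 percentage points lower from compound 1 to compound 2 (beyond the scatter), in which an aryl group on that nitrogen was exchanged for ethyl. Compound 3 reverses that exchange with a different aryl group, so a large step upward in this assay is expected, of roughly the size seen before, although a single pair gives no way to tell how closely 3-fluoro-2-methoxyphenyl will follow 3-fluorophenyl. The step of a number 75 percentage points higher from compound 2 to compound 3 (beyond the scatter) is therefore the estimate, with a wide range. For compound 3 the expected value is 75%, between 30% and 98%.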

Compound 3, a percentage reported as inhibition, at one concentration (the size of the read-out at that concentration, not a potency): 12%
The estimate for compound 3 lay 63 percentage points above the measured number, and the stated range ends above it.
By their numbers in this assay, from the lowest: compound 2; then compound 3; then compound 1.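

In this assay, an aryl group on the amide-type nitrogen in the ring does not by itself restore a high number: there is a number 12 percentage points higher from compound 2 to compound 3 (beyond the scatter), so 3-fluoro-2-methoxyphenyl regains only a modest part of the ground that separates ethyl from 3-fluorophenyl. The larger change lies in a single replacement on that aryl group, methoxy in place of hydrogen on an aromatic carbon, which gives a number 82 percentage points lower from compound 1 to compound 3 (beyond the scatter); within these compounds, what the aryl group carries matters at least as much as its presence. Nothing measured here accounts for this loss.

The compounds shown leave open whether the low number belongs to methoxy specifically, or whether hydroxy, chloro or the longer ethoxy in its place would also fall so far below compound 1 at 94%. Also open, on these data alone, is whether an unsubstituted phenyl, a benzyl or a cyclohexyl on the same nitrogen would stay near compound 1 or near compound 2 at 0%.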